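The source may report more compounds than this note shows. Statements on the series, on what has been measured and on what is new or still open speak of the compounds shown alone.

Measured compounds:
Compound 1 `N#Cc1ccc(-c2cnc3[nH]cc(-c4nnc(-c5ccc(F)cc5)o4)c(=O)c3c2)cc1`: 18.9%
Compound 2 `O=c1c(-c2nnc(-c3ccc(F)cc3)o2)c[nH]c2ncc(-c3cccnc3)cc12`: 19.7%

Two compounds sharing one core were tested in a functional assay on HCT-116 cells (Homo sapiens) for inhibition, read by MTT assay, with a stated time of 24 h, tested at 10 uM; a higher number here means more inhibition of growth at the concentration tested, a lower number less inhibition of growth. Compound 1 gives 18.9% in this assay, and compound 2 gives 19.7%. Within the data shown here, the one step between them, a number 0.8 percentage points higher from compound 1 to compound 2 (within the scatter), is within the scatter, so the two numbers are to be read as equal, and compound 2 cannot be set apart from compound 1 on the figures available.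

Compound 3 `O=c1c(-c2nnc(-c3ccc(F)cc3)o2)c[nH]c2ncc(-c3ccncc3)cc12` has not yet been measured. It differs from compound 2 in one place: pyridin-4-yl in place of pyridin-3-yl on an aromatic carbon. Among the measured compounds shown here, the only step known so far, the one from compound 1 to compound 2, exchanged a whole group on the same aromatic carbon and left this assay unchanged beyond the scatter. For the measured compounds named here, no measured step moves a ring nitrogen within a pyridinyl group, so nothing in the data points to a shift in either direction for compound 3. The step from compound 2 to compound 3 is therefore expected to be a number 0.3 percentage points higher from compound 2 to compound 3 (within the scatter), none beyond the scatter. Compound 3 is estimated at 20% in this assay, with a range from 8% to 32%.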

Compound 3, percent growth inhibition at one concentration: 20.5%
The estimate for compound 3 lay 0.5 percentage points below the measured number; measured number inside the range.
By their numbers in this assay, from the lowest: compounds 1, 2 and 3 (each within the scatter of the next).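

Placing the ring nitrogen differently within the pyridinyl group, with pyridin-4-yl in place of pyridin-3-yl on the same aromatic carbon, gives in this assay a number 0.8 percentage points higher from compound 2 to compound 3 (within the scatter), so this change cannot be told apart from no change. Among these compounds, exchanging the 4-cyanophenyl group directly for pyridin-4-yl gives a number 1.6 percentage points higher from compound 1 to compound 3 (within the scatter), which means that all three groups tried at this position read as equal in this assay, whereas the earlier compounds offered only a single exchange and no shift of the ring nitrogen. No measurement is available that would explain this result.

As far as these compounds go, all three compounds carry a six-membered aromatic ring at this position, so it remains open whether an amine, a carboxylic acid or a longer chain on this aromatic carbon would move the number in this assay beyond the scatter. Also open, from the compounds shown here alone, is how the number would respond to a change elsewhere in the molecule, for example if a methoxy group or a hydrogen took the place of the fluorine on the 4-fluorophenyl group, which all three compounds share.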